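The compounds below may be only part of what the source reports. "The series", "measured", "known", "first", "only" and "open" are said of these compounds alone.

Notes on the series. Compound 1 `O=C(O)c1ccc(C(=O)/C=C/c2ccc3c(c2)B(O)OC3)cc1` carries a carboxy group on an aromatic carbon of the ring attached to the carbonyl; in an ADME assay on L929 cells (Mus musculus) for cytotoxicity, read by resazurin assay, with a stated time of 72 h (a lower number here means a stronger inhibitor, a higher number a weaker inhibitor), compound 1 gives > 10 ug/mL, which is a limit of the assay and not a number. Compound 2 `O=C(/C=C/c1ccc2c(c1)B(O)OC2)c1ccc(O)cc1` carries a hydroxy group in its place; in this assay compound 2 gives > 10 ug/mL, again only a limit. Compound 3 `COc1ccc(C(=O)/C=C/c2ccc3c(c2)B(O)OC3)cc1OC` varies the same ring further; in this assay compound 3 gives > 10 ug/mL, also a limit. Within the data shown here, the single step between measured neighbours, hydroxy in place of carboxy on an aromatic carbon, is a step that the two limits leave unreadable from compound 1 to compound 2, so its size cannot be read. Compound 2 therefore stands at the limit of > 10 ug/mL in this assay, at which 3 of the 3 values shown sit. Compound 4 `O=C(/C=C/c1ccc2c(c1)B(O)OC2)c1cccc(F)c1` is the next member: 3-fluorophenyl in place of 4-hydroxyphenyl on a carbonyl carbon. Among the measured compounds shown here, no measured step bears on this change, and every value so far sits at the limit, so no step beyond the scatter is expected; the expected step is a step that the limit leaves unreadable from compound 2 to compound 4. The estimate for compound 4 in this assay is 20 ug/mL, expected to lie between 8 ug/mL and 60 ug/mL.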

Compound 4, half-maximal inhibitory concentration: > 10 ug/mL
Compound 4: no number, only a limit (the forecaster's own chance of this, stated with the estimate: 80%); the middle value lies beyond the limit too.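

Compound 4 gives only a limit in this assay, as compound 2 does, so no step can be read between compound 2 and compound 4: the limit of > 10 ug/mL in this assay, at which 4 of the 4 values shown sit.

The compounds shown leave open how far any of them lies past that limit, and whether any change to the ring attached to the carbonyl gives a readable value.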